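The source may hold more compounds than are shown below. What is called first, only, known or untested is meant among the compounds shown, and "the series" means these compounds.

Measured so far in a functional assay on HT-29 cells (Homo sapiens) for cytotoxicity, read by MTT assay, with a stated time of 72 h; a higher number here means a weaker inhibitor, a lower number a stronger inhibitor:
compound 1 `CN(C)CCn1cnnc1-c1cc(Oc2ccc(NC(=O)N/N=C/c3c(Cl)cccc3Cl)cc2F)ccn1` gives 280 nM
compound 2 `COc1ccc(/C=N/NC(=O)Nc2ccc(Oc3ccnc(-c4nncn4CCN(C)C)c3)c(F)c2)c(OC)c1OC` gives 3970 nM
compound 3 `CN(C)CCn1cnnc1-c1cc(Oc2ccc(NC(=O)N/N=C/c3ccccc3)cc2F)ccn1` gives 1120 nM

Compound 3 holds the second highest number of the three. Its nearest neighbour is compound 2, with a step of a 3.5-fold lower number from compound 2 to compound 3 (0.55 log units; beyond the scatter) between them, and the furthest is compound 1, with a step of a 4.0-fold higher number from compound 1 to compound 3 (0.60 log units; beyond the scatter). The third measured step, a 14-fold higher number from compound 1 to compound 2 (1.15 log units; beyond the scatter), likewise concerns only the group on the carbon with a double bond to nitrogen.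

Compound 4 `Cn1ncnc1-c1cc(Oc2ccc(NC(=O)N/N=C/c3ccccc3)cc2F)ccn1` differs from compound 3 elsewhere: 1-methyl-1H-1,2,4-triazol-5-yl in place of 4-(2-(dimethylamino)ethyl)-4H-1,2,4-triazol-3-yl on an aromatic carbon, on an aromatic carbon of a six-membered aromatic ring with 1 nitrogen, next to the ring nitrogen and meta to a large group. Among the compounds with values here, none of the measured steps touches this part of the shared core, so no step bears directly on the change. Within the data shown here, the only guide is that the three measured compounds spread over a modest range, which leaves the effect of a change at this position unknown. In this assay compound 4 is therefore expected to sit close to compound 3, with a step of a 1.3-fold higher number from compound 3 to compound 4 (0.13 log units; within the scatter), which is an estimate rather than a reading. The expected value for compound 4 is 1500 nM, within a range of 450 nM to 5000 nM.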

Compound 4, half-maximal inhibitory concentration: 30200 nM
Estimate against measurement, compound 4: 20-fold (1.30 log units) below; the whole stated range lies below it.
By their numbers in this assay, from the lowest: compound 1; then compound 3; then compound 2; then compound 4.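

In this assay, within the data shown here, the result shows that the group on the aromatic carbon next to the ring nitrogen, which none of the earlier compounds varied, strongly affects the read-out, with a 27-fold higher number from compound 3 to compound 4 (1.43 log units; beyond the scatter) as the measured step. That step is of the same order as a 14-fold higher number from compound 1 to compound 2 (1.15 log units; beyond the scatter) at the group on the carbon with a double bond to nitrogen, so both parts of the molecule matter here, yet the new change alters the triazole isomer and removes the 2-(dimethylamino)ethyl chain together, leaving fewer heavy atoms. Nothing available here accounts for the loss of activity.

The compounds shown do not separate the triazole isomer from the side chain, a question that 4-methyl-4H-1,2,4-triazol-3-yl, or a 2-(dimethylamino)ethyl chain on the 1H-1,2,4-triazol-5-yl ring, would address, while a primary amine or a longer chain ending in dimethylamino would test the role of the chain's end and length. From the compounds shown here alone, it also remains open whether the same change would cost as much with 2,6-dichlorophenyl in place of the phenyl group.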